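Swapping a Chain Methyl for an Amide Tail

The source may report more compounds than this note shows. Statements on the series, on what has been measured and on what is new or still open speak of the compounds shown alone.

Compound 3 `C=CCc1cc(C(C)=O)c(O)cc1OCCCCCC` stands lowest of the three measured compounds in an assay on isolated protein for binding affinity to leukotriene B4 receptor 1 (Homo sapiens), tested at 1 uM; on this read-out lower numbers stand for less inhibition and higher numbers for more inhibition at the one concentration tested (going by the name of the read-out): compound 3 gives 9%, while compound 2 `C=CCc1cc(C(C)=O)c(O)cc1OCCCCC` gives 23% and compound 1 `C=CCc1cc(C(C)=O)c(O)cc1OCCCCCCCCC#N` gives 50%. Compound 4 `C=CCc1cc(C(C)=O)c(O)cc1OCCCCCC(=O)N(C)C` differs from compound 3 by dimethylcarbamoyl in place of methyl on a saturated chain carbon, five bonds along the chain from an oxygen on an aromatic ring. Going by the values given here, three measured steps bear on this. Removing a nitrile-ended chain extension lowered inhibition, a number 27 percentage points lower from compound 1 to compound 2 (beyond the scatter) and a number 41 percentage points lower from compound 1 to compound 3 (beyond the scatter), and adding a methyl alone lowered it further, a number 14 percentage points lower from compound 2 to compound 3 (beyond the scatter). A chain that ends in a group carrying a carbonyl and a nitrogen may behave more like the nitrile-ended chain of compound 1 than like a bare methyl, so a rise is expected, a number 26 percentage points higher from compound 3 to compound 4 (beyond the scatter). Compound 4 is therefore estimated at 35%, with a range from 10% to 60%.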

Compound 4, a percentage reported as inhibition, at one concentration (the size of the read-out at that concentration, not a potency): 54%
The estimate for compound 4 lay 19 percentage points below the measured number, within the range that was stated.
By their numbers in this assay, from the lowest: compound 3; then compound 2; then compounds 1 and 4 (each within the scatter of the next).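

In this assay, ending the chain in dimethylcarbamoyl gives a clear gain over both plain alkyl chains (a number 45 percentage points higher from compound 3 to compound 4 (beyond the scatter); a number 31 percentage points higher from compound 2 to compound 4 (beyond the scatter)). The step from the nitrile-ended chain stays within the scatter (a number 4 percentage points higher from compound 1 to compound 4 (within the scatter)), so these two different chain ends cannot be told apart at this position. No measurement shown explains the gain. The compounds shown leave open whether the carbonyl or the two nitrogen methyls matter more. A carboxylic acid, a primary amide or an amine at the chain end would help separate the two.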